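A few compounds are considered here, and "the series" means these few. Any claim that something is new, unique, unknown or untested is made for them only; others in the source may bear on it.

Going by the values given here, compound 1, with structure `Cc1ccc(-c2c(OCC(=O)Nc3cccc4ccccc34)oc3ccccc3c2=O)cc1`, is the only compound in this set with a number to its name: in an ADME assay on A2780 cells (Homo sapiens) for inhibition, read by MTT assay, with a stated time of 72 h (a lower number here means a stronger inhibitor of growth, a higher number a weaker inhibitor of growth), compound 1 gives 68700 nM. Two companions were tested in the same setting without a result being reported. Compound 2, `COc1cccc(/C=C/C(=O)c2ccc(OCC(=O)Nc3ccc(OC)c(OC)c3)cc2)c1`, shows "not determined" (no result reported) in this assay, and compound 3, `COc1ccc(NC(=O)COc2ccc(C(=O)/C=C/c3c(F)cccc3F)cc2)cc1OC`, likewise shows "not determined" (no result reported). Compound 4, `COc1ccc(-c2c(OCC(=O)Nc3cccc4ccccc34)oc3ccccc3c2=O)cc1OC`, has not yet been measured. It differs from compound 1 in one place: 3,4-dimethoxyphenyl in place of 4-methylphenyl on an aromatic carbon. Among the compounds with values here, with no pair of measured compounds to show what such a swap does, the expected step from compound 1 to compound 4 is small, and compound 4 is estimated at a 1.4-fold lower number from compound 1 to compound 4 (0.14 log units; within the scatter). The expected value for compound 4 is 50000 nM, within a range of 15000 nM to 150000 nM.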

Compound 4, concentration for 50% growth inhibition: 43600 nM
For compound 4 the middle estimate is 1.1-fold (0.06 log units) above the measured one; the measured number falls inside the stated range.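

In this assay the swap gives a 1.6-fold lower number from compound 1 to compound 4 (0.20 log units; within the scatter). At this position on the shared core, then, 3,4-dimethoxyphenyl and 4-methylphenyl cannot be told apart, even though the larger group brings hydrogen-bond acceptors that the smaller one lacks. Nothing measured here offers an explanation for this result. Still open, going by these compounds, is whether a single methoxy group would read the same as the pair. On these data alone, it is also open whether an amine or a carboxylic acid on this phenyl ring would move the number beyond the scatter.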